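Swapping Methoxy for Methyl on a Thiophene-Based Series

The source may report more compounds than this note shows. Statements on the series, on what has been measured and on what is new or still open speak of the compounds shown alone.

Of the compounds shown here, three built on one shared core have been tested in a functional assay, with a stated time of 150 min, tested at 30 ug/mL; a lower number here means a weaker effect, a higher number a stronger effect of the compound at the concentration tested. Compound 1 `COC(=O)c1c(Nc2ccc(C)cc2)sc(C(=O)c2ccc(OC)cc2)c1C` is reported in this assay as "not active" (no number reported), so no single number stands for it; the same is true of compound 3 `COC(=O)c1c(Nc2ccc(Cl)cc2)sc(C(=O)c2ccc(OC)cc2)c1C`, which this assay also reports as "not active" (no number reported). Only compound 2 `COC(=O)c1c(Nc2ccc(OC)cc2)sc(C(=O)c2ccc(OC)cc2)c1C` carries a number: in this assay compound 2 gives 20.5%. Compound 1 therefore stands among the entries for which no figure was recorded, and nothing more precise can be said about its place relative to compound 2.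

Compound 4 `COC(=O)c1c(Nc2ccc(C)cc2)sc(C(=O)c2ccc(C)cc2)c1C` has not yet been measured. It differs from compound 1 in one spot (methyl in place of methoxy on an aromatic carbon), on an aromatic carbon of a six-membered aromatic ring of carbon only. Among the compounds with values here, no measured pair in this set shows the same change, so the size of the step in this assay is unknown; given that compound 1 gave "not active" (no number reported), the expectation is either no reported number again or a weak effect that does not rise beyond the usual scatter. On that basis compound 4 is estimated at 5%, within a range from 0% to 20%, with a real chance that only "not active" is reported.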

Compound 4, a percentage reported as activity, at one concentration (the size of the read-out at that concentration, not a potency): "not active" (no number reported)
Compound 4 has no reported number here; the estimate stays without a comparison.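

Within the data shown here, compound 4, like compound 1, is reported as not active with no number, so no step between compound 1 and compound 4 can be read. No other data here bear on this result. The compounds shown leave open whether going from 4-methoxyphenyl to 4-methylphenyl changes the effect at all in this series.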